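A few compounds are considered here, and "the series" means these few. Any claim that something is new, unique, unknown or untested is made for them only; others in the source may bear on it.

Series notes. The compounds under discussion share a core carrying a nitrile and two ring-bound nitrogens; all are assessed in an assay on isolated protein for inhibition of protein kinase C theta type (Homo sapiens), read by TR-FRET, with a stated time of 2 h; a lower number here means a stronger inhibitor, a higher number a weaker inhibitor. Compound 1 `N#Cc1cnc(NCc2cnccc2C(F)(F)F)cc1N[C@H]1CC[C@H](O)CC1` gives 350 nM in this assay, the highest of the two numbers recorded so far. Among the measured compounds shown here, its nearest neighbour, compound 2 `N#Cc1cnc(NCc2ccccc2C(F)(F)F)cc1N[C@H]1C[C@@H](C(N)=O)C1`, gives 150 nM in this assay, a lower number that lies beyond the usual scatter; compound 2 differs from compound 1 in more than one place, so the two values show only that a compound of this series can sit lower than compound 1.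

The next compound, compound 3 `CC1(C)[C@@H](Nc2cc(NCc3cnccc3C(F)(F)F)ncc2C#N)C[C@H]1C(N)=O`, has not yet been measured. Relative to compound 1 the change is 3-carbamoyl-2,2-dimethylcyclobutyl in place of 4-hydroxycyclohexyl on a nitrogen on an aromatic ring. For the measured compounds named here, no single-point step between measured compounds exists that would anchor this change, so the direction rests on the two values alone. The expected step is a 1.4-fold lower number from compound 1 to compound 3 (0.15 log units; within the scatter), a modest move downward that is estimated to sit near the edge of the scatter rather than clearly beyond it. Compound 3 is accordingly estimated at 250 nM in this assay, with a plausible range from 80 nM to 800 nM, to be replaced once the measurement is in hand.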

Compound 3, half-maximal inhibitory concentration: 140 nM
Compound 3: the middle estimate sits 1.8-fold (0.25 log units) above what was measured, within the range that was stated.
By their numbers in this assay, from the lowest: compounds 3 and 2 (each within the scatter of the next); then compound 1.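

Among the compounds shown here, the (3-carbamoyl-2,2-dimethylcyclobutyl)amino group in place of (4-hydroxycyclohexyl)amino gives the first single-place reading at this nitrogen on the aromatic ring (this assay), a step of a 2.5-fold lower number from compound 1 to compound 3 (0.40 log units; beyond the scatter) with the rest of the molecule unchanged. Compounds 1 and 2 differ in more than one place and could not show this, whereas the present pair shows that the number at this position responds to the substituent and that a four-membered carbon ring with a carbamoyl group and two extra methyl groups is accepted here in place of a six-membered carbon ring with a hydroxyl group. Ring size, the carbamoyl group and the two methyl groups all change together, and no measurement on hand bears on the reason for the step.

The compounds shown leave open how much of the step belongs to each of these three features, which a 3-carbamoylcyclobutyl group without the methyl groups or a 4-carbamoylcyclohexyl group would help to separate. As far as these compounds go, it also remains open how a carboxylic acid or a primary amine would read in place of the carbamoyl group on the dimethylcyclobutyl ring.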